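Cyclic amine restored in place of the sulfonamide chain

The source may hold more compounds than are shown below. What is called first, only, known or untested is meant among the compounds shown, and "the series" means these compounds.

Going by the values given here, compound 2 `CC(C)(C)c1ccc(C(=O)N2CCC3(CC2)C(=O)N(CC(=O)NCNS(C)(=O)=O)CN3c2ccccc2)cc1` holds the higher of the two numbers measured so far: in an assay on HEK293 cells for displacement of a labelled ligand from NPC1-like intracellular cholesterol transporter 1 (Homo sapiens) (on this read-out lower numbers stand for stronger inhibition and higher numbers for weaker inhibition), compound 2 gives 3200 nM. Among the compounds with values here, its only neighbour is compound 1 `CC(C)(C)c1ccc(C(=O)N2CCC3(CC2)C(=O)N(CC(=O)N2CCC(CCO)CC2)CN3c2ccccc2)cc1`, which in this assay gives 2600 nM; the step of a 1.2-fold higher number from compound 1 to compound 2 (0.09 log units; within the scatter) lies within the scatter. Compound 3 `CC(C)(C)c1ccc(C(=O)N2CCC3(CC2)C(=O)N(CC(=O)N2CCCC(CO)C2)CN3c2ccccc2)cc1` is not yet measured. It differs from compound 2 by 3-(hydroxymethyl)piperidin-1-yl in place of ((methanesulfonamido)methyl)amino on a carbonyl carbon. Within the data shown here, the single measured step that bears on this change is a 1.2-fold higher number from compound 1 to compound 2 (0.09 log units; within the scatter), in which the 4-(2-hydroxyethyl)piperidin-1-yl group gave way to the open ((methanesulfonamido)methyl)amino chain with hardly any movement in the number. Compound 3 brings back a piperidine of closely related kind, so no step beyond the scatter is expected in this assay. The estimated step of a 1.2-fold lower number from compound 2 to compound 3 (0.07 log units; within the scatter) is thus expected to be small. Compound 3 is expected to give 2700 nM, within a range from 1200 nM to 6000 nM.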

Compound 3, half-maximal inhibitory concentration: 8200 nM
For compound 3 the middle estimate is 3.0-fold (0.48 log units) below the measured one, outside the stated range (above it).
By their numbers in this assay, from the lowest: compounds 1 and 2 (each within the scatter of the next); then compound 3.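

In this assay the group on this carbonyl carbon can move the number after all: the return to a piperidine gives a 2.6-fold higher number from compound 2 to compound 3 (0.41 log units; beyond the scatter) and so passes the scatter, which the earlier step did not. Having a piperidine there does not by itself set the number, since 3-(hydroxymethyl)piperidin-1-yl in place of 4-(2-hydroxyethyl)piperidin-1-yl gives a 3.2-fold higher number from compound 1 to compound 3 (0.50 log units; beyond the scatter) while the open chain of compound 2 stays within the scatter of compound 1. Nothing measured here gives a reason for this loss.

From the compounds shown here alone, compound 1 and compound 3 differ both in where the side chain sits on the piperidine and in its length, so which of the two carries the change stays open. Neither 4-(hydroxymethyl)piperidin-1-yl nor 3-(2-hydroxyethyl)piperidin-1-yl is among the compounds shown, and either would separate these two features.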